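An amino for methoxy swap on the chlorinated compound

The source may report more compounds than this note shows. Statements on the series, on what has been measured and on what is new or still open speak of the compounds shown alone.

Measured in a functional assay on L1210 cells (Mus musculus) for inhibition; on this read-out higher numbers stand for weaker inhibition and lower numbers for stronger inhibition:
compound 1 `COC(=O)c1ccc(OC)c(C/C=C(\C)CCC(=O)O)c1O`: > 100000 nM
compound 2 `COc1ccc(C(N)=O)c(O)c1C/C=C(\C)CCC(=O)O`: > 100000 nM
compound 3 `COC(=O)c1cc(Cl)c(OC)c(C/C=C(\C)CCC(=O)O)c1O`: 61000 nM

For the measured compounds named here, compound 3 carries the only actual number in the set, 61000 nM. For compound 1, > 100000 nM is a limit of the assay. For compound 2, > 100000 nM is also a limit of the assay. Chloro in place of hydrogen on an aromatic carbon gave an at least 1.6-fold lower number from compound 1 to compound 3 (0.21 log units; that floor lies within the scatter).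

Compound 4 `COc1c(Cl)cc(C(N)=O)c(O)c1C/C=C(\C)CCC(=O)O` follows from compound 3 by one change, amino in place of methoxy on a carbonyl carbon, or methoxycarbonyl to carbamoyl. The same change has been measured once, as a step that the two limits leave unreadable from compound 1 to compound 2, so it offers no size to carry over. With no readable precedent, no change beyond the scatter is expected in this assay, in either direction, though compound 4 could also reach the limit. The expected step is a 1.2-fold higher number from compound 3 to compound 4 (0.09 log units; within the scatter). The estimate for compound 4 is 75000 nM, with an expected range of 30000 nM to 160000 nM.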

Compound 4, half-maximal inhibitory concentration: > 100000 nM
Compound 4 ended at the assay's limit; the forecaster's own chance of this, stated with the estimate: 45%; at least 1.3-fold (0.12 log units) between middle value and limit.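

In this assay, the swap of methoxy for amino on a carbonyl carbon now has a readable floor, which the unchlorinated pair could not give: an at least 1.6-fold higher number from compound 3 to compound 4 (0.21 log units; that floor lies within the scatter). From the compounds shown here alone, compound 4 sits at a limit of the assay, so the true size of this step is unknown, and its floor alone does not show a change beyond the scatter. The steps from compound 1 to compound 2 and from compound 2 to compound 4 cannot be read, and the measurements leave little room for comparison: the limit of > 100000 nM in this assay, at which 3 of the 4 values shown sit.

Going by these compounds, how far the carbamoyl compounds lie past that limit remains open, and so does whether chloro has any effect on them. Also open, on these data alone, is how hydroxy or methylamino in place of methoxy on a carbonyl carbon would read on the chlorinated compound.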